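Dropping the Methoxy From the Chalcone Aryl Ring

The source may report more compounds than this note shows. Statements on the series, on what has been measured and on what is new or still open speak of the compounds shown alone.

In a functional assay on HCT-15 cells (Homo sapiens) for inhibition (on this read-out higher numbers stand for weaker inhibition of growth and lower numbers for stronger inhibition of growth), compound 2 `COc1cc(/C=C/C(=O)c2cccc(-n3cc(-c4ccccc4)[nH]c3=O)c2)ccc1O` gives 2730 nM; this stands second highest of three numbers. Compound 1 `COc1cc(/C=C/C(=O)c2cccc(-n3cc(-c4ccccc4)[nH]c3=O)c2)cc(OC)c1OC` gives 1130 nM in this assay, and compound 3 `COc1ccc(-c2cn(-c3cccc(C(=O)/C=C/c4ccc(O)c(OC)c4)c3)c(=O)[nH]2)cc1` gives 3150 nM. Within the data shown here, the one step that changes a single place, methoxy in place of hydrogen on an aromatic carbon, gave a 1.2-fold higher number from compound 2 to compound 3 (0.06 log units; within the scatter). Compound 4 `O=C(/C=C/c1cccc(O)c1)c1cccc(-n2cc(-c3ccccc3)[nH]c2=O)c1` differs from compound 2 as 3-hydroxyphenyl in place of 4-hydroxy-3-methoxyphenyl on a double-bonded chain carbon bound to a double-bonded chain carbon. Among the measured compounds shown here, no measured step removes a methoxy from this ring, so the bearing of the step from compound 2 to compound 3 is indirect; since compound 1 with three methoxy groups gives 1130 nM, a somewhat higher number is expected. Compound 4 is estimated at 4000 nM, between 1500 nM and 12000 nM. The expected step is a 1.5-fold higher number from compound 2 to compound 4 (0.17 log units; within the scatter).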

Compound 4, concentration for 50% growth inhibition: 3100 nM
Compound 4: the middle estimate sits 1.3-fold (0.11 log units) above what was measured; the range from low to high includes it.
By their numbers in this assay, from the lowest: compound 1; then compounds 2, 4 and 3 (each within the scatter of the next).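

Placing 3-hydroxyphenyl in place of 4-hydroxy-3-methoxyphenyl on this chain carbon gave a 1.1-fold higher number from compound 2 to compound 4 (0.06 log units; within the scatter) in this assay, the first step shown at this position, and it leaves the two compounds indistinguishable. The swap removes the methoxy and shifts the hydroxy at once, so the result cannot be assigned to either alteration alone. Nothing available here accounts for this result. As far as these compounds go, what remains open is how this position would respond to an amine or a carboxylic acid on this ring. The separate contributions of the methoxy and the hydroxy also remain unresolved.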